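Inverting the ring stereocentre of compound 3

The compounds below may be only part of what the source reports. "The series", "measured", "known", "first", "only" and "open" are said of these compounds alone.

Compound 1 `C[C@@H]1COC(c2cccc(OC(=O)NC3CCCCC3)c2)=N1`: 16% in an assay on membranes from cerebellum (strain Wistar) for inhibition of Monoglyceride lipase (Rattus norvegicus), read by HPLC, tested at 100 uM; a lower number here means less inhibition, a higher number more inhibition at the concentration tested (going by the name of the read-out); compound 2 `O=C(NC1CCCCC1)Oc1cccc(C2=N[C@H](Cc3ccccc3)CO2)c1`: 14% in this assay; compound 3 `COC(=O)[C@H]1COC(c2cccc(OC(=O)NC3CCCCC3)c2)=N1`: 35% in this assay.

Compound 3 stands highest of the three numbers; compound 1 is nearest and compound 2 furthest, both beyond the scatter. Among the compounds with values here, the only measured step, a number 2 percentage points lower from compound 1 to compound 2 (within the scatter), lies within the scatter and concerns a phenyl group, not configuration, so no measured step bears on the change to compound 4 `COC(=O)[C@@H]1COC(c2cccc(OC(=O)NC3CCCCC3)c2)=N1`. The change is the two compounds have the same atoms and bonds and differ only in configuration as drawn: 1 of 1 stereo elements differ; a stereocentre at a saturated ring carbon is drawn R in compound 3 and S in compound 4. With no stereochemical comparison available, the size and direction of the step are uncertain; compound 4 is expected to land at 25%, within 8% to 45%, a step of a number 10 percentage points lower from compound 3 to compound 4 (within the scatter) that is an estimate only.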

Compound 4, a percentage reported as inhibition, at one concentration (the size of the read-out at that concentration, not a potency): 25%
For compound 4 middle estimate and measured number coincide at the digits printed, within the range that was stated.
By their numbers in this assay, from the lowest: compounds 2, 1, 4 and 3 (each within the scatter of the next, the first and the last beyond it).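

In this assay, inverting the stereocentre at this saturated ring carbon gives a number 10 percentage points lower from compound 3 to compound 4 (within the scatter), so the two configurations are not resolved from each other with methoxycarbonyl in place. This comparison concerns configuration alone: the fact that compounds 3 and 4 differ only in the configuration as drawn. With the S configuration, methoxycarbonyl in place of benzyl gives a number 11 percentage points higher from compound 2 to compound 4 (beyond the scatter), whereas methoxycarbonyl in place of methyl gives a number 9 percentage points higher from compound 1 to compound 4 (within the scatter), so only the first of these two replacements is resolved.

From the compounds shown here alone, whether a carboxylic acid or an ethyl ester on this ring carbon would read differently remains open. Also open, going by these compounds, is whether the two configurations would separate with either of those groups.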